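A halogen swap at the edge of compound 1

A few compounds are considered here, and "the series" means these few. Any claim that something is new, unique, unknown or untested is made for them only; others in the source may bear on it.

Compound 1 `Nc1ccccc1NC(=O)c1ccc(NC(=S)NCc2cncc(Br)c2)cc1` is the only entry with a real number. In a functional assay on HCT-116 cells (Homo sapiens) for cytotoxicity, read by MTT assay, with a stated time of 72 h (on this read-out lower numbers stand for stronger inhibition and higher numbers for weaker inhibition), compound 1 gives 9200 nM. The second entry, compound 2 `Nc1ccccc1NC(=O)c1ccc(Cn2cc(-c3ccc(NC(=O)NCc4cccnc4)cc3)nn2)cc1`, sits at the limit of > 100000 nM in this assay, at which 1 of the 2 values shown sits. In this assay compound 2 gives > 100000 nM, which is a limit of the assay rather than a number, so compound 2 offers no scale for comparison.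

The unmeasured compound 3 `Nc1ccccc1NC(=O)c1ccc(NC(=S)NCc2cncc(F)c2)cc1` keeps everything in compound 1 except one change: fluoro in place of bromo on an aromatic carbon. For the measured compounds named here, no measured pair shows this kind of swap, so the expected size of the step rests on the change alone. The step of a 1.4-fold higher number from compound 1 to compound 3 (0.15 log units; within the scatter) is expected to be small, at most a modest loss that may not rise beyond the usual scatter. Compound 3 is therefore estimated at 13000 nM, with a range from 5000 nM to 35000 nM.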

Compound 3, half-maximal inhibitory concentration: 15000 nM
For compound 3 the middle estimate is 1.2-fold (0.06 log units) below the measured one; low and high end bracket the measured number.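

In this assay, fluoro in place of bromo gives a 1.6-fold higher number from compound 1 to compound 3 (0.21 log units; within the scatter). For the compounds shown here, this is the first direct comparison at this position, which the earlier compounds could not provide, and it shows that the two halogens cannot be told apart here: on the pyridine ring, 5-bromopyridin-3-yl and 5-fluoropyridin-3-yl read alike in this cell test. Nothing measured here offers an explanation for this result.

Still open, on these data alone, is how this position responds to a group other than a halogen, such as an amine, a nitrile or a carboxylic acid, or to a plain hydrogen with no substituent at all. A single pair also cannot show whether the same swap would read alike on a different core.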